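The source may hold more compounds than are shown below. What is called first, only, known or untested is meant among the compounds shown, and "the series" means these compounds.

Of the compounds shown here, two have been measured in a functional assay on MCF7 cells (Homo sapiens) for inhibition, read by MTT assay, with a stated time of 72 h; on this read-out higher numbers stand for weaker inhibition and lower numbers for stronger inhibition. Compound 1 `COc1ccc(Nc2nc(SCc3cn(CC(=O)NC(=O)Nc4ccccn4)nn3)nc(-c3ccc(C)cc3)c2C#N)cc1` gives 23400 nM, and compound 2 `COc1ccccc1Nc1nc(SCc2cn(CC(=O)NC(=O)Nc3ccccn3)nn2)nc(-c2ccc(C)cc2)c1C#N` gives 19700 nM. Within the data shown here, the only step so far, a 1.2-fold lower number from compound 1 to compound 2 (0.07 log units; within the scatter), exchanges one methoxyphenyl for another on a nitrogen on an aromatic ring and lies within the scatter. Compound 2 thus holds the lowest of the two numbers, but its gap to compound 1 is within the scatter, so no order between them can be read.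

Compound 3 `Cc1ccc(Nc2nc(SCc3cn(CC(=O)NC(=O)Nc4ccccn4)nn3)nc(-c3ccc(C)cc3)c2C#N)cc1` has not yet been measured in this assay. Against compound 2 the change is 4-methylphenyl in place of 2-methoxyphenyl on a nitrogen on an aromatic ring. Among the measured compounds shown here, no measured step covers this exchange: the one step in hand only swapped methoxyphenyl for methoxyphenyl and left the number within the scatter. The data give no direction for replacing the methoxy substituent by a methyl, so the expected step is a 1.0-fold higher number from compound 2 to compound 3 (0.01 log units; within the scatter), none beyond the scatter, with the range widened for an untested exchange. Compound 3 is expected to give 20000 nM in this assay, within a range from 8000 nM to 50000 nM.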

Compound 3, half-maximal inhibitory concentration: 39600 nM
Compound 3: the middle estimate sits 2.0-fold (0.30 log units) below what was measured; low and high end bracket the measured number.
By their numbers in this assay, from the lowest: compounds 2, 1 and 3 (each within the scatter of the next).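

In this assay, the first exchange away from a methoxy group on this aryl ring reads as a 1.7-fold higher number from compound 1 to compound 3 (0.23 log units; within the scatter) for methyl in place of methoxy on an aromatic carbon, and as a 2.0-fold higher number from compound 2 to compound 3 (0.30 log units; within the scatter) for 4-methylphenyl in place of 2-methoxyphenyl on a nitrogen on an aromatic ring. Both steps lie within the scatter, so the three compounds cannot be put in order, and a change that removes the oxygen and its hydrogen-bond acceptor from this group has so far produced no step beyond the scatter. No measured property of these compounds bears on this result, so it stays a plain comparison of numbers.

The compounds shown leave open whether any substituent on this phenyl ring can produce a step beyond the scatter, as only methoxy and methyl appear here, and an amine, a carboxylic acid or a longer alkyl chain would test that more widely. They also do not separate the effect of the group from that of its place on the ring, since methyl appears only in 4-methylphenyl.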